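Working notes: from compound 2 to compound 3

The source may report more compounds than this note shows. Statements on the series, on what has been measured and on what is new or still open speak of the compounds shown alone.

Measured so far in a physicochemical assay for lipophilicity; a higher number here means a more lipophilic compound, a lower number a more polar compound
compound 1 `C[C@H]1CC[C@@H]2[C@@H](OC(=O)[C@]23CC(c2ccc(Br)cc2)N(c2ccccc2)O3)[C@]2(C)C(=O)C=C[C@@]12O` gives 4
compound 2 `COc1ccc(C2C[C@@]3(ON2c2ccccc2)C(=O)O[C@@H]2[C@H]3CC[C@H](C)[C@]3(O)C=CC(=O)[C@@]23C)cc1` gives 3.25

Compound 2 holds the lower of the two numbers, and the gap to compound 1 lies beyond the scatter. Compound 3 `Cc1ccccc1C1C[C@@]2(ON1c1ccccc1)C(=O)O[C@@H]1[C@H]2CC[C@H](C)[C@]2(O)C=CC(=O)[C@@]12C` has not been measured yet. Its structure departs from that of compound 2 by 2-methylphenyl in place of 4-methoxyphenyl on a saturated ring carbon in the exchange of 2-methylphenyl in place of 4-methoxyphenyl on a saturated ring carbon. Among the compounds with values here, one measured step bears on this, namely a number 0.75 log units lower from compound 1 to compound 2 (beyond the scatter) with methoxy in place of bromo on an aromatic carbon. Within the data shown here, that step brought the methoxy in, and here it leaves, though no measured step covers the entering methyl. A rise of modest size is therefore expected in this assay and the expected step is a number 0.45 log units higher from compound 2 to compound 3 (beyond the scatter) with wide uncertainty. For compound 3 the estimate is 3.7 with an expected range from 3.2 to 4.2 for now.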

Compound 3, partition coefficient: 3.64
The estimate for compound 3 lay 0.06 log units above the measured number, within the range that was stated.
By their numbers in this assay, from the lowest: compound 2; then compound 3; then compound 1.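

In this assay, the exchange on the saturated ring carbon next to the ring nitrogen gives a number 0.39 log units higher from compound 2 to compound 3 (beyond the scatter) on going from 4-methoxyphenyl to 2-methylphenyl, and a number 0.36 log units lower from compound 1 to compound 3 (beyond the scatter) on going from 4-bromophenyl to 2-methylphenyl. This one position now carries three groups with separated numbers, 2-methylphenyl standing between the other two, whereas the earlier pair offered only a single gap. Both new steps change the substituent and its place on the phenyl ring together, which the earlier step did not do, and nothing available bears on the reason for either step.

How much of each step belongs to the methyl and how much to its place on the ring stays open, as 4-methylphenyl is not among the compounds shown. Also open, as far as these compounds go, is where a phenyl ring carrying an amine or a carboxylic acid would fall in this order.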